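From 2-acetylethyl to 2-cyanoethenyl: a cytotoxicity estimate

The source may hold more compounds than are shown below. What is called first, only, known or untested is meant among the compounds shown, and "the series" means these compounds.

In an ADME assay on TZM cells (Homo sapiens) for cytotoxicity, read by XTT assay, with a stated time of 4 days (on this read-out higher numbers stand for lower toxicity in this test and lower numbers for higher toxicity in this test), compound 1 `Cc1cc(Br)cc(C)c1Oc1ccc(N)c(Nc2ccc(C#N)cc2)n1`, which carries a bromo group, gives 15500 nM. Compound 2 `Cc1cc(C#CC2CC2)cc(C)c1Oc1ccc(N)c(Nc2ccc(C#N)cc2)n1`, with 2-cyclopropylethynyl in that place, gives 7450 nM, and compound 3 `CC(=O)CCc1cc(C)c(Oc2ccc(N)c(Nc3ccc(C#N)cc3)n2)c(C)c1`, with 2-acetylethyl, gives 9250 nM. Compound 3 stands within the scatter of both others, as a 1.7-fold lower number from compound 1 to compound 3 (0.22 log units; within the scatter) and a 1.2-fold higher number from compound 2 to compound 3 (0.09 log units; within the scatter) show. Going by the values given here, the only step beyond the scatter is the modest 2.1-fold lower number from compound 1 to compound 2 (0.32 log units; beyond the scatter).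

Compound 4 `Cc1cc(/C=C/C#N)cc(C)c1Oc1ccc(N)c(Nc2ccc(C#N)cc2)n1` has 2-cyanoethenyl in place of the 2-acetylethyl of compound 3, on an aromatic carbon (2-cyanoethenyl in place of 2-acetylethyl on an aromatic carbon). The closest guide is the exchange of one longer group for another, a 1.2-fold higher number from compound 2 to compound 3 (0.09 log units; within the scatter), which stayed within the scatter. All three measured steps are small, but they are only three, so the range must stay wide. No step beyond the scatter is expected in this assay, and the estimated step is a 1.2-fold lower number from compound 3 to compound 4 (0.06 log units; within the scatter). Compound 4 is expected at about 8000 nM, with an estimated range from 3500 nM to 17000 nM.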

Compound 4, half-maximal cytotoxic concentration: 9750 nM
Compound 4: middle estimate off by 1.2-fold (0.09 log units), on the low side, within the range that was stated.
By their numbers in this assay, from the lowest: compounds 2, 3, 4 and 1 (each within the scatter of the next, the first and the last beyond it).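

In this assay, 2-cyanoethenyl on this aromatic carbon reads within the scatter of all three earlier groups: the 2-acetylethyl of compound 3 (a 1.1-fold higher number from compound 3 to compound 4 (0.02 log units; within the scatter)), the 2-cyclopropylethynyl of compound 2 (a 1.3-fold higher number from compound 2 to compound 4 (0.12 log units; within the scatter)) and the bromo of compound 1 (a 1.6-fold lower number from compound 1 to compound 4 (0.20 log units; within the scatter)). Compound 4 therefore lies within the scatter of both compound 1 and compound 2, although those two are beyond the scatter of each other, so it does not sharpen the one difference seen so far. Going from 2-acetylethyl to 2-cyanoethenyl replaces an oxygen with a nitrogen and adds a triple bond while the hydrogen-bond acceptor count stays the same, and no data here explain why the numbers stay so close.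

From the compounds shown here alone, how an amine or a carboxylic acid on this carbon would read remains open. So does whether a longer chain would stay within the scatter of these four compounds.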